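Compound 3: phenyl to 2-chlorophenyl

A few compounds are considered here, and "the series" means these few. Any claim that something is new, unique, unknown or untested is made for them only; others in the source may bear on it.

Measured in a functional assay on the whole organism with Mus musculus as the target; on this read-out higher numbers stand for an effect only at larger amounts of compound and lower numbers for an effect already at smaller amounts:
Compound 1 `Cc1nnc(CNC(=O)CN)n1-c1ccc(Cl)cc1C(=O)c1ccccc1F`: 0.25 mg/kg
Compound 2 `Cc1nnc(CNC(=O)CN)n1-c1ccc(Cl)cc1C(=O)c1ccccc1`: 0.72 mg/kg
Not yet measured:
Compound 3 `Cc1nnc(CNC(=O)CN)n1-c1ccc(Cl)cc1C(=O)c1ccccc1Cl`

Within the data shown here, compound 2, at 0.72 mg/kg, holds the higher of the two numbers, and compound 1 is its only neighbour. The move to compound 3 is chloro in place of hydrogen on an aromatic carbon, with chloro in place of hydrogen on an aromatic carbon, ortho to a large group. Among the measured compounds shown here, one measured step bears on it: a 2.9-fold higher number from compound 1 to compound 2 (0.46 log units; beyond the scatter), a modest change beyond the scatter, with hydrogen in place of fluoro on that same aromatic carbon. For the measured compounds named here, no measured compound yet carries chloro there, so this reading rests on fluoro alone. A similar modest step towards a lower number is therefore expected in this assay. The expected step is a 2.7-fold lower number from compound 2 to compound 3 (0.43 log units; beyond the scatter). Compound 3 is estimated at 0.27 mg/kg, with an expected range of 0.1 mg/kg to 0.7 mg/kg.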

Compound 3, dose for half-maximal effect: 0.27 mg/kg
For compound 3 middle estimate and measured number coincide at the digits printed; the range from low to high includes it.
By their numbers in this assay, from the lowest: compounds 1 and 3 (each within the scatter of the next); then compound 2.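

In this assay, among these compounds, chloro on this aromatic carbon, ortho to a large group, gives a 2.7-fold lower number from compound 2 to compound 3 (0.43 log units; beyond the scatter) and thereby shows that fluoro is not the only group whose presence there, in place of hydrogen, goes with a lower number. Chloro in place of fluoro gives a 1.1-fold higher number from compound 1 to compound 3 (0.03 log units; within the scatter) and so leaves the two groups indistinguishable on this read-out. No measurement is available that explains the effect of either group at this position.

From the compounds shown here alone, whether a bromo, methyl or methoxy group at the same place would also give a lower number than hydrogen remains open. It is also unknown whether the step would persist if the amine of the shared side chain were replaced by a carboxylic acid.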